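The source may hold more compounds than are shown below. What is called first, only, known or untested is meant among the compounds shown, and "the series" means these compounds.

Two thiourea compounds built on the same core have been measured. Compound 1 `COc1ccc(NC(=S)Nc2ccc3[nH]ccc3c2)cc1` gives 67.6% in an ADME assay on isolated protein for inhibition of peroxidase (Raphanus sativus), read by fluorescence and Amplex Red, tested at 5 uM (on this read-out higher numbers stand for a weaker effect at the one concentration tested and lower numbers for a stronger effect), and compound 2 `CC(=O)Nc1ccc(NC(=S)Nc2ccc3[nH]ccc3c2)cc1` gives 68.1% there. On these two numbers compound 1 has the lower one, but the step of a number 0.5 percentage points higher from compound 1 to compound 2 (within the scatter) is within the scatter, so the two compounds cannot be told apart on this read-out.

Compound 3 `COc1ccc(NC(=S)Nc2ccc3[nH]ccc3c2)cc1OC` has not yet been measured. It differs from compound 1 by methoxy in place of hydrogen on an aromatic carbon.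

Among the measured compounds shown here, no measured step changes this same place in the same way; the only step at hand, a number 0.5 percentage points higher from compound 1 to compound 2 (within the scatter), swaps the group at the other position and barely moves the number. With so little to go on, the expectation for the step of a number 0.6 percentage points lower from compound 1 to compound 3 (within the scatter) is that it stays within the scatter. Compound 3 is therefore estimated at 67%, with a range from 54% to 80%.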

Compound 3, a percentage reported as activity, at one concentration (the size of the read-out at that concentration, not a potency): 61%
Beside the measured number, compound 3's estimate is 6 percentage points above it; low and high end bracket the measured number.
By their numbers in this assay, from the lowest: compounds 3, 1 and 2 (each within the scatter of the next).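

On the core of compound 1, a hydrogen on the aromatic carbon ortho to a methoxy group and meta to a large group is replaced by methoxy, and this gives a number 6.6 percentage points lower from compound 1 to compound 3 (within the scatter) in this assay. The earlier pair only exchanged one group for another on a carbon that already carried a substituent, whereas this step shows that this second ring carbon can take a methoxy group with no change beyond the scatter on this read-out. Nothing available explains the result or shows what the added methoxy does here.

On these data alone, whether a different group on this carbon, such as an amine, a carboxylic acid or a longer alkoxy chain, would move the number beyond the scatter remains open. So does whether the same added methoxy would behave alike with the acetamido group of compound 2 in place of the existing methoxy.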